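Series notes: side-chain change at the sulfur

A few compounds are considered here, and "the series" means these few. Any claim that something is new, unique, unknown or untested is made for them only; others in the source may bear on it.

Compound 1 `CC(C)COc1ccc(-c2c(C#N)c(N)nc(SCC(N)=O)c2C#N)cc1` and compound 2 `N#Cc1c(N)nc(SCc2nc3ccccc3[nH]2)c(C#N)c1-c1ccc(OCC2CC2)cc1` share one core. In an assay on CHO cells for displacement of a labelled ligand from adenosine receptor A3 (Homo sapiens), read by scintillation counting, with a stated time of 120 min, tested at 1 uM (a lower number here means less inhibition, a higher number more inhibition at the concentration tested (going by the name of the read-out)), compound 1 gives 9% and compound 2 gives 1%; compound 2 stands lowest of the two numbers, but its gap to compound 1 is within the scatter, so no order is claimed. Compound 3 `CNC(=O)CSc1nc(N)c(C#N)c(-c2ccc(OCC3CC3)cc2)c1C#N` is not yet measured and differs from compound 2 in one place: methylcarbamoyl in place of 1H-benzimidazol-2-yl on a saturated chain carbon bound to a sulfur. Both measured numbers sit low, and the expected step in this assay is a number 6 percentage points higher from compound 2 to compound 3 (within the scatter), nothing beyond the scatter. Compound 3 is expected to give 7% in this assay, within 0% to 20%.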

Compound 3, a percentage reported as inhibition, at one concentration (the size of the read-out at that concentration, not a potency): 3%
Estimate against measurement, compound 3: 4 percentage points above; measured number inside the range.
By their numbers in this assay, from the lowest: compounds 2, 3 and 1 (each within the scatter of the next).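

In this assay, for the compounds shown here, methylcarbamoyl in place of 1H-benzimidazol-2-yl on a saturated chain carbon bound to a sulfur gives a number 2 percentage points higher from compound 2 to compound 3 (within the scatter) as the first one-place reading at this position. A group with two aromatic rings and an open-chain group with no ring therefore cannot be told apart here at the concentration tested. No measurement bears on why this is so.

As far as these compounds go, whether a carboxylic acid, an amine or a longer chain at this carbon would give a step beyond the scatter remains open.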